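Sulfonyl to Carbonyl Where Both Measured Parents Sit at the Limit

The compounds below may be only part of what the source reports. "The series", "measured", "known", "first", "only" and "open" are said of these compounds alone.

Compound 1 `CCOC(=O)Cn1ncc2c(Nc3ccc(NC(=O)c4ccccc4)cc3)ncnc21`: in a functional assay on cells (Homo sapiens) for inhibition, read by MTT assay, with a stated time of 72 h (a higher number here means a weaker inhibitor, a lower number a stronger inhibitor), compound 1 gives > 100 ug/mL, which is a limit of the assay and not a number.
Compound 2 `O=C(O)Cn1ncc2c(Nc3ccc(NS(=O)(=O)c4ccccc4)cc3)ncnc21`: in this assay compound 2 gives > 100 ug/mL, again a limit of the assay.

For the measured compounds named here, compound 2 therefore stands nowhere on a scale of numbers: its value is a limit, and the only other value shown is a limit too (the limit of > 100 ug/mL in this assay, at which 2 of the 2 values shown sit). Going by the values given here, no step between measured compounds can be drawn from such a pair, so there is no measured change to lean on.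

Compound 3 `O=C(O)Cn1ncc2c(Nc3ccc(NC(=O)c4ccccc4)cc3)ncnc21` differs from compound 2 in a single place: benzoyl in place of phenylsulfonyl on a nitrogen on an aromatic ring. Compound 3 thus carries the acid of compound 2 together with the amide of compound 1.

Because both measured values sit at the limit (the limit of > 100 ug/mL in this assay, at which 2 of the 2 values shown sit), the step is expected to be none beyond the usual scatter; the expected change from compound 2 to compound 3 is a step that the limit leaves unreadable from compound 2 to compound 3, which means no real movement. Compound 3 is expected to give about 150 ug/mL in this assay, within 50 ug/mL to 500 ug/mL, and most likely the assay will again report only a limit for compound 3.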

Compound 3, half-maximal inhibitory concentration: > 100 ug/mL
Compound 3 was reported as a limit; the forecaster's own chance of this, stated with the estimate: 80%; the middle value lies beyond the limit too.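

In this assay compound 3 gives > 100 ug/mL as a limit of the assay and not a number. For the compounds shown here, no step from compound 1 or compound 2 to compound 3 can be read, because every value shown is a limit: the limit of > 100 ug/mL in this assay, at which 3 of the 3 values shown sit.
The compounds shown leave open whether benzoyl in place of phenylsulfonyl, or hydrogen in place of ethyl, changes inhibition at all.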